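A few compounds are considered here, and "the series" means these few. Any claim that something is new, unique, unknown or untested is made for them only; others in the source may bear on it.

Compound 1, with the structure `O=C(Nc1ccccc1)c1cccc(/C=C2\CC(=O)N(c3ccccc3)C2=O)c1`, is the starting point of this step. In an ADME assay on HCT-116 cells (Homo sapiens) for cytotoxicity, read by MTT assay, with a stated time of 72 h (on this read-out higher numbers stand for weaker inhibition and lower numbers for stronger inhibition), compound 1 gives only a limit, > 100000 nM, which is the edge of what the test can report rather than a number. Going by the values given here, the only other measured compound, compound 2 with the structure `CCc1cccc(NC(=O)c2cccc(/C=C3\CC(=O)N(Cc4ccccc4)C3=O)c2)c1`, gives 80600 nM in this assay, so both measured compounds sit at the weak end of this read-out, and compound 1 stands at the limit of > 100000 nM in this assay, at which 1 of the 2 values shown sits.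

The unmeasured compound 3, with the structure `O=C(Nc1ccc(F)cc1)c1cccc(/C=C2\CC(=O)N(c3ccccc3)C2=O)c1`, differs from compound 1 in one place: fluoro in place of hydrogen on an aromatic carbon.

Among the compounds with values here, since no measured pair shows how such a change plays out here, no step beyond the scatter is expected, and the step from compound 1 to compound 3 is estimated as an at least 1.1-fold lower number from compound 1 to compound 3 (0.04 log units; that floor lies within the scatter). Compound 3 is therefore expected to give about 90000 nM in this assay, within a range from 40000 nM to 200000 nM.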

Compound 3, half-maximal inhibitory concentration: > 100000 nM
Compound 3 was reported as a limit; the forecaster's own chance of this, stated with the estimate: 55%; middle value at least 1.1-fold (0.04 log units) away from the limit.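

Compound 1 and compound 3 both give only a limit in this assay, so no step can be read between them: the limit of > 100000 nM in this assay, at which 2 of the 3 values shown sit.

The compounds shown leave open whether fluoro in place of hydrogen changes this read-out at all.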